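This account rests on a few compounds, and the source may have more. Where it says the series, first, only, none or still open, it means among the compounds named here.

Measured so far in a physicochemical assay (Homo sapiens) for solubility, with a stated time of 18 h, at pH 7.4; on this read-out higher numbers stand for higher solubility and lower numbers for lower solubility:
- compound 1 `CCN(CC)c1ccc(/C=C2/SC(N(c3ccccc3)c3ccccc3)=NC2=O)cc1` gives 0.01 ug/mL
- compound 2 `CN1CCN(c2ccc(/C=C3/SC(N(c4ccccc4)c4ccccc4)=NC3=O)cc2)CC1` gives 0.11 ug/mL
- compound 3 `CCN(CC)c1ccc(/C=C2/SC(N(C)c3ccccc3)=NC2=O)cc1` gives 0.01 ug/mL

Compound 4 `CN1CCN(c2ccc(/C=C3/SC(N(C)c4ccccc4)=NC3=O)cc2)CC1` is still to be measured. Relative to compound 3 the change is 4-methylpiperazin-1-yl in place of diethylamino on an aromatic carbon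

The same change has already been made once, from compound 1 to compound 2: 4-methylpiperazin-1-yl in place of diethylamino on an aromatic carbon That step gave an 11-fold higher number from compound 1 to compound 2 (1.04 log units; beyond the scatter).

The two cores differ in one place, methyl in place of phenyl on a nitrogen on an aromatic ring and this difference gave no change at the digits printed from compound 1 to compound 3 (within the scatter), so compound 3 starts from the same level as compound 1.

With a single earlier instance of the change, and with compound 1 and compound 3 level, the step from compound 3 to compound 4 is expected to be about a 10-fold higher number from compound 3 to compound 4 (1.00 log units; beyond the scatter); this rests on the earlier step of an 11-fold higher number from compound 1 to compound 2 (1.04 log units; beyond the scatter). Compound 4 is therefore estimated at 0.1 ug/mL, with the likely range 0.03 ug/mL to 0.4 ug/mL.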

Compound 4, solubility: 18.9 ug/mL
For compound 4 the middle estimate is 190-fold (2.28 log units) below the measured one; measured number outside the range, above it.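

In this assay, 4-methylpiperazin-1-yl in place of diethylamino gives an 11-fold higher number from compound 1 to compound 2 (1.04 log units; beyond the scatter) and also a 1900-fold higher number from compound 3 to compound 4 (3.28 log units; beyond the scatter) so the direction carries between these two cores while the size does not. With 4-methylpiperazin-1-yl present, methyl in place of phenyl on the nitrogen gives a 170-fold higher number from compound 2 to compound 4 (2.24 log units; beyond the scatter) while with diethylamino present it gives no change at the digits printed from compound 1 to compound 3 (within the scatter) so the two changes do not add independently in these four compounds. No measurement at hand bears on the reason for this difference between the cores.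

As far as these compounds go, whether morpholine or piperidine on that aromatic carbon follows the same pattern remains open. Also open, from the compounds shown here alone, is how an ethyl group or a longer chain on the nitrogen compares with methyl.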